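A few compounds are considered here, and "the series" means these few. Any claim that something is new, unique, unknown or untested is made for them only; others in the source may bear on it.

Measured compounds:
compound 1 `Nc1cc2c(-n3nc(-c4ccccn4)nc3N)ncnc2cc1Cl` gives > 40000 nM in an assay on MCF7 cells for inhibition of Serine-protein kinase ATM (Homo sapiens), read by immunofluorescence, with a stated time of 1 h (a lower number here means a stronger inhibitor, a higher number a weaker inhibitor), a limit of the assay.
compound 2 `COc1cc2ncnc(-n3nc(-c4ccccn4)nc3N)c2cc1N` gives > 40000 nM in this assay, again a limit.
compound 3 `COc1cc2nc(N)nc(-n3nc(-c4ccccn4)nc3N)c2cc1OC` gives 2100 nM in this assay.

Compound 2 stands at the limit of this assay, not at a number, and the limit of > 40000 nM in this assay, at which 2 of the 3 values shown sit, holds for it as for compound 1. The step that the two limits leave unreadable from compound 1 to compound 2 therefore cannot be read. Within the data shown here, compound 3, which differs from compound 2 in two places, is the only compound with a number, and its value shows that the shared core can reach measurable inhibition.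

Compound 4 `COCCOc1cc2c(-n3nc(-c4ccccn4)nc3N)ncnc2cc1OC` arises from compound 2 by 2-methoxyethoxy in place of amino on an aromatic carbon. Among the measured compounds shown here, no measured step bears on this change directly; the one step between measured compounds, from compound 1 to compound 2, is unreadable. For the measured compounds named here, the only guide is that compound 4, like compound 3, carries alkoxy groups on both of the neighbouring carbons of its carbocyclic ring, whereas compound 2 carries an amino group there. Compound 4 is therefore expected to land somewhere near the value of compound 3, with the step of an at least 8.0-fold lower number from compound 2 to compound 4 (0.90 log units; beyond the scatter) not readable in size, since compound 2 sits at a limit. For compound 4 the estimate is 5000 nM, within 1000 nM to 40000 nM.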

Compound 4, half-maximal inhibitory concentration: 1200 nM
For compound 4 the middle estimate is 4.2-fold (0.62 log units) above the measured one; low and high end bracket the measured number.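

Putting 2-methoxyethoxy in place of amino on this aromatic carbon, ortho to a methoxy group, gives an at least 33-fold lower number from compound 2 to compound 4 (1.52 log units; beyond the scatter) in this assay. Among these compounds, this is the first step that can be read, since the earlier step between the two compounds at the limit cannot, and it shows that this position can carry a chain and that the change moves the read-out by a large amount. The true size of the step stays unknown because compound 2 sits at a limit and not at a number: the limit of > 40000 nM in this assay, at which 2 of the 4 values shown sit.

The single change removes the amino group with its hydrogen-bond donor and brings in a longer chain with no donor, so the compounds shown cannot separate the loss of the amino group from the gain of the chain. Going by these compounds, whether a plain methoxy, a hydroxyl, a 2-hydroxyethoxy or a 2-(dimethylamino)ethoxy group at this place would give a similar value stays open, as does whether the neighbouring methoxy group shares in the step.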